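A Side-Chain Swap on an Amine Nitrogen

The compounds below may be only part of what the source reports. "The series", "measured", "known", "first", "only" and "open" are said of these compounds alone.

Measured so far:
compound 1 `NNCc1cc(O)n2nc(N)c([N+](=O)[O-])c2n1` gives 26.5 ug/mL
compound 2 `Nc1nn2c(O)cc(CNNCCO)nc2c1[N+](=O)[O-]` gives > 50 ug/mL

In a functional assay on K562 cells (Homo sapiens) for inhibition (on this read-out higher numbers stand for weaker inhibition of growth and lower numbers for stronger inhibition of growth), compound 1 gives 26.5 ug/mL. For compound 2 this assay returns only a limit, > 50 ug/mL, not a number. Compound 2 thus sits at the limit of > 50 ug/mL in this assay, at which 1 of the 2 values shown sits. For the measured compounds named here, the single measured step, an at least 1.8-fold higher number from compound 1 to compound 2 (0.27 log units; that floor lies within the scatter), concerns a different group on that amine nitrogen, so no step speaks directly to the next change. Compound 3 `Nc1nn2c(O)cc(CNNC(N)S)nc2c1[N+](=O)[O-]` differs from compound 2 by amino(sulfanyl)methyl in place of 2-hydroxyethyl on an amine nitrogen. With nothing measured for this swap, the expected step in this assay is a number no higher from compound 2 to compound 3 (the limit leaves the size open), none beyond the scatter. Compound 3 is therefore estimated at 50 ug/mL, in a range from 20 ug/mL to 150 ug/mL.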

Compound 3, concentration for 50% growth inhibition: > 50 ug/mL
Compound 3: no number, only a limit; the forecaster's own chance of this, stated with the estimate: 60%; the middle value lies on the limit itself.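

In this assay, compound 3 also returns only a limit, > 50 ug/mL, so a second group on this amine nitrogen gives no number: the limit of > 50 ug/mL in this assay, at which 2 of the 3 values shown sit.

Amino(sulfanyl)methyl in place of hydrogen gives an at least 1.8-fold higher number from compound 1 to compound 3 (0.27 log units; that floor lies within the scatter), so this swap, like the first, shows no clear loss of growth inhibition. The step between compound 2 and compound 3 cannot be read.

From the compounds shown here alone, how far the true values of compound 2 and compound 3 lie from their limits stays open. So does what a longer chain or a carboxylic acid on this nitrogen would give.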